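Fluorine on the anilide ring of an aryl-ether quinolone

A few compounds are considered here, and "the series" means these few. Any claim that something is new, unique, unknown or untested is made for them only; others in the source may bear on it.

Compound 1 `O=C(Nc1ccc(Oc2ccnc3[nH]ccc23)cc1)c1cn(-c2ccc(Br)cc2)c2ccccc2c1=O` and compound 2 `COc1ccc(-n2cc(C(=O)Nc3ccc(Oc4ccnc5[nH]ccc45)cc3)c(=O)c3ccccc32)cc1` share a common core and differ only in the group on the distal aryl ring. In a functional assay on A549 cells (Homo sapiens) for inhibition, read by MTT assay, with a stated time of 72 h (on this read-out lower numbers stand for stronger inhibition and higher numbers for weaker inhibition), compound 1 gives 450 nM, while compound 2 gives 4980 nM; this is an 11-fold higher number from compound 1 to compound 2 (1.04 log units; beyond the scatter). Among the two numbers shown, compound 2 therefore stands at the highest value, with compound 1 the nearest neighbour.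

Compound 3 `COc1ccc(-n2cc(C(=O)Nc3ccc(Oc4ccnc5[nH]ccc45)c(F)c3)c(=O)c3ccccc32)cc1` is derived from compound 2 by a single change: fluoro in place of hydrogen on an aromatic carbon. Within the data shown here, the one measured step, from compound 1 to compound 2, concerns a different ring and a different kind of group, so no measured step bears directly on this change. Without a relevant precedent, the step is expected to be a 1.2-fold lower number from compound 2 to compound 3 (0.10 log units; within the scatter), that is, none beyond the scatter. For compound 3 the estimate is 4000 nM, within a range from 1500 nM to 12000 nM.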

Compound 3, half-maximal inhibitory concentration: 4150 nM
Compound 3: middle estimate off by 1.0-fold (0.02 log units), on the low side; the measured number falls inside the stated range.
By their numbers in this assay, from the lowest: compound 1; then compounds 3 and 2 (each within the scatter of the next).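

In this assay, fluoro in place of hydrogen on this aromatic carbon, ortho to a large group and meta to a large group, gives a 1.2-fold lower number from compound 2 to compound 3 (0.08 log units; within the scatter), so compound 2 and compound 3 cannot be told apart on this read-out. Among these compounds, the only earlier step, an 11-fold higher number from compound 1 to compound 2 (1.04 log units; beyond the scatter), concerned a different place in the molecule, so this is the first reading at this position, and here a single fluorine atom leaves the result inside the usual scatter. Nothing measured here bears on why the change has so little effect.

On these data alone, whether a chloro, a methoxy or an amine at the same carbon would also stay within the scatter remains open. As far as these compounds go, it is also open whether fluoro would behave the same way with the bromo group of compound 1 on the distal aryl ring.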